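This account rests on a few compounds, and the source may have more. Where it says the series, first, only, none or still open, it means among the compounds named here.

Measured compounds:

Compound 1, `COc1ccc2c(c1)/C(=C\C(=O)OC(C)(C)C)C(=O)N2`: 78.7%
Compound 2, `COc1cccc2c1NC(=O)/C2=C/C(=O)OC(C)(C)C`: 77.8%
Compound 3, `CC(C)(C)OC(=O)/C=C1/C(=O)Nc2ccc(Cl)cc21`: 78.5%

Of the compounds shown here, three have been tested in a functional assay on SW480 cells (Homo sapiens) for inhibition, read by CCK-8 assay, with a stated time of 72 h, tested at 20 uM; on this read-out lower numbers stand for less inhibition of growth and higher numbers for more inhibition of growth at the one concentration tested. Compound 1 gives 78.7%, compound 2 gives 77.8% and compound 3 gives 78.5%; all three numbers lie within the scatter of one another, so no order among them can be read. Compound 1 and compound 3 differ in one place, (chloro in place of methoxy on an aromatic carbon), and the step of a number 0.2 percentage points lower from compound 1 to compound 3 (within the scatter) is within the scatter. Compound 2 shares its atoms with compound 1 but joined differently; the difference between the two cores is not broken down here.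

Compound 4, `CC(C)(C)OC(=O)/C=C1/C(=O)Nc2c(Cl)cccc21`, is not yet measured in this assay. It stands to compound 2 as compound 3 stands to compound 1: chloro in place of methoxy on an aromatic carbon. This is the same kind of change, though the place differs: in compound 3 the chloro sits meta to a fused ring and para to a fused ring, whereas in compound 4 it sits ortho to a fused ring and meta to a fused ring. Because the earlier step of a number 0.2 percentage points lower from compound 1 to compound 3 (within the scatter) was within the scatter, the step from compound 2 to compound 4 is expected to be about a number 0.3 percentage points lower from compound 2 to compound 4 (within the scatter). Compound 4 is therefore estimated at 77.5% in this assay, between 68% and 86%.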

Compound 4, percent growth inhibition at one concentration: 78%
Estimate against measurement, compound 4: 0.5 percentage points below, within the range that was stated.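

In this assay chloro in place of methoxy on the core of compound 2 gives a number 0.2 percentage points higher from compound 2 to compound 4 (within the scatter) and so agrees with the step seen on the core of compound 1: the same change on two cores in this assay, a number 0.2 percentage points lower (within the scatter) from compound 1 to compound 3 and a number 0.2 percentage points higher (within the scatter) from compound 2 to compound 4, 0.4 percentage points apart, within the scatter of two such steps.
On these two cores, then, the change leaves the number within the scatter, even though the group sits in a different place on each core. This does not show that the change is without effect in general: it rests on two pairs of compounds in one cell line at one concentration, and a step too small to read says nothing about how a larger step would carry from core to core.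

The compounds shown carry only methoxy or chloro on the aromatic ring, and all of them keep the tert-butyl ester. From the compounds shown here alone, it stays open how an amine or a nitrile on that ring, or a carboxylic acid in place of the ester, would read in this assay.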